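Swapping a para substituent on the shared aryl group

The source may hold more compounds than are shown below. What is called first, only, known or untested is meant among the compounds shown, and "the series" means these compounds.

Measured compounds:
compound 1, `Cc1nc(-c2cccc(C(F)(F)F)c2)sc1COc1ccc2c(c1)OCC2CC(=O)O`, 35.7%
compound 2, `Cc1nc(-c2ccc(C(F)(F)F)cc2)sc1COc1ccc2c(c1)OCC2CC(=O)O`, 50.4%

Going by the values given here, compound 2 gives 50.4% in a functional assay on CHO cells for agonist activity at Free fatty acid receptor 1 (Homo sapiens), read by FLIPR and calcium flux, tested at 100 nM (on this read-out higher numbers stand for a stronger effect at the one concentration tested and lower numbers for a weaker effect), the higher of the two numbers known so far. Among the compounds with values here, compound 1 sits below it: the single measured step, a number 14.7 percentage points higher from compound 1 to compound 2 (beyond the scatter), moves the substituent on the outer ring from one position to another and is beyond the scatter. Compound 3, `COc1ccc(-c2nc(C)c(COc3ccc4c(c3)OCC4CC(=O)O)s2)cc1`, keeps that outer ring and the rest of compound 2 and changes only the group on it: methoxy in place of trifluoromethyl on an aromatic carbon.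

Within the data shown here, no measured step exchanges one group for another at this place; the step from compound 1 to compound 2 only moves the same group and so speaks to the position, not to the nature of the substituent. Without such a precedent, the expectation is a modest shift, possibly downward, but with little confidence in the direction. For compound 3 the estimated change is a number 10.4 percentage points lower from compound 2 to compound 3 (beyond the scatter), and its value is expected to be about 40%, within a range from 15% to 65%.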

Compound 3, a percentage reported as activity, at one concentration (the size of the read-out at that concentration, not a potency): 46.8%
Estimate against measurement, compound 3: 6.8 percentage points below; low and high end bracket the measured number.
By their numbers in this assay, from the lowest: compound 1; then compounds 3 and 2 (each within the scatter of the next).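

Here the group itself changes for the first time: in this assay, methoxy in place of trifluoromethyl gives a number 3.6 percentage points lower from compound 2 to compound 3 (within the scatter) and so, at this one concentration, the two groups cannot be told apart, even though methoxy has fewer heavy atoms and adds a hydrogen-bond acceptor. The comparison with the other compound runs a number 11.1 percentage points higher from compound 1 to compound 3 (beyond the scatter) and is harder to read alone, since group and position change together, but it places both the 4-methoxyphenyl and the 4-(trifluoromethyl)phenyl compounds beyond the scatter above the 3-(trifluoromethyl)phenyl compound. Nothing available explains why trifluoromethyl and methoxy read alike here.

From the compounds shown here alone, whether the tolerance seen here extends to quite different groups at this place, such as an amine, a carboxylic acid or a longer chain like butoxy, remains open. Also open, going by these compounds, is whether methoxy would track trifluoromethyl in the position that group holds in compound 1, and whether compound 2 and compound 3 would still match across a range of concentrations, since a single concentration gives the size of an effect and not a potency.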